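Same Chlorine Shift on a Second Core, Low Inhibition

The source may report more compounds than this note shows. Statements on the series, on what has been measured and on what is new or still open speak of the compounds shown alone.

Measured compounds:
compound 1 `COc1ccc(C2N=C(SCc3cccc(Cl)c3)NC(C)=C2C(=O)Nc2ccc(F)cc2)cc1OC` gives 5.2%
compound 2 `COc1ccc(C2N=C(SCc3ccc(Cl)cc3)NC(C)=C2C(=O)Nc2ccc(F)cc2)cc1OC` gives 5.7%
compound 3 `CC1=C(C(=O)Nc2ccc([N+](=O)[O-])cc2)C(c2cccc([N+](=O)[O-])c2)N=C(SCc2cccc(Cl)c2)N1` gives 4.1%

In a functional assay on the whole organism (artery, strain albino) with Rattus norvegicus as the target, with a stated time of 30 min, at a dose of 10 mg/kg by the oral route (a higher number here means more inhibition at the dose given (going by the name of the read-out), a lower number less inhibition), compound 1 gives 5.2%, and compound 2 differs from it only by 4-chlorophenyl in place of 3-chlorophenyl on a saturated chain carbon bound to a sulfur, a change that produced a number 0.5 percentage points higher from compound 1 to compound 2 (within the scatter). Compound 3, built on a different core, gives 4.1% in this assay; the difference between the two cores is not broken down here. Compound 4 `CC1=C(C(=O)Nc2ccc([N+](=O)[O-])cc2)C(c2cccc([N+](=O)[O-])c2)N=C(SCc2ccc(Cl)cc2)N1` is not yet measured and relates to compound 3 through (4-chlorophenyl in place of 3-chlorophenyl on a saturated chain carbon bound to a sulfur), the same change seen between compound 1 and compound 2, made at the same place. Because the earlier step was a number 0.5 percentage points higher from compound 1 to compound 2 (within the scatter), the expected step from compound 3 to compound 4 is a number 0.5 percentage points higher from compound 3 to compound 4 (within the scatter), likewise small. Compound 4 is therefore estimated at 4.6%, with a range of 0% to 12%.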

Compound 4, a percentage reported as inhibition, in the whole organism at one dose (the size of the read-out at that dose, not a potency): 3.1%
For compound 4 the middle estimate is 1.5 percentage points above the measured one, and the stated range covers the measured number.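

In this assay, putting 4-chlorophenyl in place of 3-chlorophenyl gives a number 1 percentage points lower from compound 3 to compound 4 (within the scatter), so the step on this core is also small. Set side by side, the two steps do not differ: the same change on two cores in this assay, a number 0.5 percentage points higher (within the scatter) from compound 1 to compound 2 and a number 1 percentage points lower (within the scatter) from compound 3 to compound 4, 1.5 percentage points apart, within the scatter of two such steps. The change therefore carries from one core to the other without a step that stands out from the scatter, but this does not show that it has a real effect on either core, nor that the two cores would respond alike to a change with a larger effect.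

The compounds shown leave open whether an amine or a carboxylic acid in place of the chlorobenzyl group would change the inhibition at this dose. They also cannot separate the two cores, which differ in more than one place.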